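A bromofluorophenyl swap against a cytotoxicity limit

A few compounds are considered here, and "the series" means these few. Any claim that something is new, unique, unknown or untested is made for them only; others in the source may bear on it.

In a functional assay on Huh-7 cells (Homo sapiens) for cytotoxicity, read by MTT assay, with a stated time of 72 h (a higher number here means that more compound is tolerated, a lower number that less compound is tolerated), compound 1 (`CCS(=O)(=O)N1CCC2(CC1)OOC1(CCCCCC1)OO2`) gives > 100 ug/mL as a limit and not a number. Compound 2 (`COc1ccc(S(=O)(=O)N2CCC3(CC2)OOC2(CCCC2)OO3)cc1`) gives > 100 ug/mL as a limit too. Compound 3 (`COc1ccc(S(=O)(=O)N2CCC3(CC2)OOC2(CCCCC2)OO3)cc1`) gives > 100 ug/mL as a limit as well, and like compound 2 it carries an aromatic ring on the sulfonyl sulfur. Compound 4 (`O=S(=O)(c1ccc(Br)cc1F)N1CCC2(CC1)OOC1(CCCCCC1)OO2`) puts 4-bromo-2-fluorophenyl in place of the ethyl of compound 1 on a sulfonyl sulfur, a change counted as 4-bromo-2-fluorophenyl in place of ethyl on a sulfonyl sulfur in full. With no numbers to compare, the expected step is an at least 1.1-fold lower number from compound 1 to compound 4 (0.04 log units; that floor lies within the scatter) and none beyond the scatter. Compound 4 is estimated at 90 ug/mL with an expected range from 40 ug/mL to 120 ug/mL in this measurement.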

Compound 4, half-maximal cytotoxic concentration: > 100 ug/mL
Compound 4 was reported as a limit; the forecaster's own chance of this, stated with the estimate: 65%; middle value at least 1.1-fold (0.04 log units) away from the limit.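

Compound 1 and compound 4 both stand as limits in this assay and not as numbers, so no step between them can be read: the limit of > 100 ug/mL in this assay, at which 4 of the 4 values shown sit.

The compounds shown leave open whether 4-bromo-2-fluorophenyl in place of ethyl on a sulfonyl sulfur changes the tolerated concentration at all, and if it does, by how much.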